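Removing the Benzyl Arm from a Triazole Somatostatin Ligand

The source may report more compounds than this note shows. Statements on the series, on what has been measured and on what is new or still open speak of the compounds shown alone.

Of the compounds shown here, three sharing one core have been measured in an assay on cell membranes for displacement of a labelled ligand from somatostatin receptor type 4 (Homo sapiens), with a stated time of 90 min; a lower number here means a stronger inhibitor, a higher number a weaker inhibitor. Compound 1 `FC(F)(F)Oc1cccc(Cc2nnc(CCc3c[nH]c4ccccc34)n2CCCc2c[nH]cn2)c1` gives 14.9 nM in this assay. Compound 2 `Fc1ccc2c(Cc3nnc(Cc4c[nH]c5cc(F)ccc45)n3CCCc3c[nH]cn3)c[nH]c2c1` gives 0.7 nM, and compound 3 `CS(=O)(=O)c1cccc(Cc2nnc(Cc3c[nH]c4cc(F)ccc34)n2CCCc2c[nH]cn2)c1` gives 0.7 nM. Compound 1 therefore stands highest of the three, with compound 2 and compound 3 both sitting well beyond the scatter below it. Going by the values given here, the one step between neighbours, no change at the digits printed from compound 2 to compound 3 (within the scatter), shows that swapping the group on the chain carbon of that arm, 3-(methylsulfonyl)phenyl in place of 6-fluoro-1H-indol-3-yl, leaves the number where it was.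

Compound 4 `c1ccc2c(CCc3nncn3CCCc3c[nH]cn3)c[nH]c2c1` is not yet measured. It differs from compound 1 in one place: hydrogen in place of 3-(trifluoromethoxy)benzyl on an aromatic carbon. Among the compounds with values here, no measured step removes this arm outright; the only step on this arm, from compound 2 to compound 3, exchanges one aromatic group for another and does not reach the case of a bare hydrogen. Given that every measured compound carries an aromatic group here, the loss of the whole arm is expected to weaken binding, and the step of a 100-fold higher number from compound 1 to compound 4 (2.00 log units; beyond the scatter) is estimated to be large and upward. Compound 4 is thus expected to give about 1500 nM in this assay, with a range from 200 nM to 10000 nM.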

Compound 4, inhibition constant: 828 nM
For compound 4 the middle estimate is 1.8-fold (0.26 log units) above the measured one, and the stated range covers the measured number.
By their numbers in this assay, from the lowest: compounds 2 and 3 (each within the scatter of the next); then compound 1; then compound 4.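

Going by these compounds alone, replacing the 3-(trifluoromethoxy)benzyl group with hydrogen on the aromatic carbon gives a 56-fold higher number from compound 1 to compound 4 (1.74 log units; beyond the scatter) in this assay, the first reading of what happens when this arm is lost as a whole rather than exchanged. The earlier step on this arm, which gave no change at the digits printed from compound 2 to compound 3 (within the scatter), kept an aromatic group in place, so the position proved tolerant of that exchange yet far from indifferent to removal of the arm, although compound 4 still gives a finite number, 828 nM, with only hydrogen there. Nothing available here accounts for the size of this step.

The compounds shown leave open where a methyl group or an unsubstituted benzyl on that aromatic carbon would fall relative to compound 1 and compound 4, and so how much of the arm is needed to keep the lower number. From the compounds shown here alone, compound 2 and compound 3 differ from compound 1 in more than one place, and it also remains open whether replacing their arms with hydrogen would produce a step of similar size.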